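A few compounds are considered here, and "the series" means these few. Any claim that something is new, unique, unknown or untested is made for them only; others in the source may bear on it.

Working notes on the series, read in a functional assay on PC-3 cells (Homo sapiens) for antiproliferative activity, read by MTT assay, with a stated time of 24 h; a lower number here means a stronger inhibitor, a higher number a weaker inhibitor. Compound 1 (`CCn1c(C(=O)NC2(CO)CC2)ccc1C(CC)(CC)c1ccc(OCS(=O)(=O)c2ccccc2)c(C)c1`) gives 3560 nM, and compound 2 (`CCn1c(C(=O)N[C@@H](C)C(=O)O)ccc1C(CC)(CC)c1ccc(OCS(=O)(=O)c2ccccc2)c(C)c1`) gives 16800 nM. Compound 2 thus holds the higher of the two numbers and is the weaker inhibitor of the pair.

Compound 3 (`CCn1c(C(=O)N[C@@H](C(=O)O)C(C)C)ccc1C(CC)(CC)c1ccc(OCS(=O)(=O)c2ccccc2)c(C)c1`) is the next to be read. Its difference from compound 2 is 1-carboxy-2-methylpropyl in place of 1-carboxyethyl on an amide-type nitrogen, with 1-carboxy-2-methylpropyl in place of 1-carboxyethyl on an amide-type nitrogen.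

Among the measured compounds shown here, one measured step bears on this change: a 4.7-fold higher number from compound 1 to compound 2 (0.67 log units; beyond the scatter). It is modest, though beyond the scatter, and it involves the same amide-type nitrogen. However, that step exchanges 1-(hydroxymethyl)cyclopropyl for 1-carboxyethyl, whereas both groups in the present change have a 1-carboxy name. For the measured compounds named here, no measured step compares two such groups, so the direction remains poorly defined. Going by the values given here, a smaller step than the one to compound 2 is expected, probably within the scatter, with only a slight lean towards a lower number.

The estimate implies an expected change a 1.3-fold lower number from compound 2 to compound 3 (0.11 log units; within the scatter). Compound 3 is expected at 13000 nM, with an estimated range of 5500 nM to 32000 nM.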

Compound 3, half-maximal inhibitory concentration: 3070 nM
For compound 3 the middle estimate is 4.2-fold (0.63 log units) above the measured one, outside the stated range (below it).
By their numbers in this assay, from the lowest: compounds 3 and 1 (each within the scatter of the next); then compound 2.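

Within the carboxy-bearing groups on this amide-type nitrogen, the side chain matters in this assay: 1-carboxy-2-methylpropyl in place of 1-carboxyethyl gives a 5.5-fold lower number from compound 2 to compound 3 (0.74 log units; beyond the scatter) and so shows that a change confined to this side chain, with the carboxy group kept, can shift the number beyond the scatter. The weak reading of compound 2 therefore cannot be assigned to the presence of a carboxy group alone, since the second step, a 1.2-fold lower number from compound 1 to compound 3 (0.06 log units; within the scatter), leaves the 1-carboxy-2-methylpropyl and 1-(hydroxymethyl)cyclopropyl groups indistinguishable in this assay. No measurement available here gives a cause for either step.

Among the compounds shown here, with only two carboxy-bearing groups, it remains open whether the trend continues with a longer or larger chain, such as 1-carboxy-3-methylbutyl or 1-carboxy-2-phenylethyl, or instead reverses. Also open, as far as these compounds go, are how the opposite configuration at the defined stereocentre would read and whether a methyl ester or primary amide in place of the carboxylic acid would keep the number of compound 3.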